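Swapping the Methoxyphenyl for Chloro-Nitrophenyl on an Inactive Pair

A few compounds are considered here, and "the series" means these few. Any claim that something is new, unique, unknown or untested is made for them only; others in the source may bear on it.

Of the compounds shown here, two have so far been tested in a functional assay on A549 cells (Homo sapiens) for antiproliferative activity, read by MTT assay, with a stated time of 48 h; on this read-out higher numbers stand for weaker inhibition and lower numbers for stronger inhibition. Compound 1 `N#CC1=C(N)Oc2c(c3nc4ccccc4nc3c3ccccc23)C12C(=O)N(Cc1cnnn1-c1ccc(N)cc1)c1ccccc12` reaches only the limit of the assay, giving > 50000 nM. Compound 2 `COc1ccc(-n2nncc2CN2C(=O)C3(C(C#N)=C(N)Oc4c(N)cc5nc6ccccc6nc5c43)c3ccccc32)cc1` likewise returns only a limit in this assay, > 50000 nM. Both results therefore sit at the same boundary, as summarized by the limit of > 50000 nM in this assay, at which 2 of the 2 values shown sit, and neither supplies a number from which a trend could be read. Compound 3 `N#CC1=C(N)Oc2c(N)cc3nc4ccccc4nc3c2C12C(=O)N(Cc1cnnn1-c1ccc(Cl)cc1[N+](=O)[O-])c1ccccc12` is the next candidate; it differs from compound 2 in one place: 4-chloro-2-nitrophenyl in place of 4-methoxyphenyl on an aromatic nitrogen. For the measured compounds named here, no step between measured compounds exists in this set, so the change has no precedent here. The expected step in this assay is a number no higher from compound 2 to compound 3 (the limit leaves the size open), none beyond the usual scatter. Compound 3 is accordingly estimated at 50000 nM, within 10000 nM to 200000 nM, and is most likely to be reported once more as a limit rather than a number.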

Compound 3, half-maximal inhibitory concentration: > 50000 nM
Compound 3 was reported as a limit (the forecaster's own chance of this, stated with the estimate: 75%); the middle value sits exactly at the limit.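

No step can be read from compound 2 to compound 3 in this assay, as both results are limits and not numbers: the limit of > 50000 nM in this assay, at which 3 of the 3 values shown sit.

The compounds shown leave open whether any group on that aromatic nitrogen would give a measured number rather than a limit.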